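Halogen exchange in a small series: working notes

This account rests on a few compounds, and the source may have more. Where it says the series, first, only, none or still open, it means among the compounds named here.

- compound 1 `COc1cc(/C=C2\CN(C)C/C(=C\c3ccc(Cl)cc3)C2=O)cc(OC)c1OC`: 14000 nM
- compound 2 `COc1cc(/C=C2\CN(C)C/C(=C\c3ccc(Br)cc3)C2=O)cc(OC)c1OC`: 15400 nM

In an ADME assay on L02 cells (Homo sapiens) for cytotoxicity, read by MTT assay, with a stated time of 24 h (on this read-out lower numbers stand for stronger inhibition and higher numbers for weaker inhibition), the two measured compounds cannot be separated, with a 1.1-fold higher number from compound 1 to compound 2 (0.04 log units; within the scatter). For the measured compounds named here, compound 2 therefore stands level with its only measured neighbour, and neither can be ranked above the other.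

Compound 3 `COc1cc(/C=C2\CN(C)C/C(=C\c3ccc(Cl)cc3Cl)C2=O)cc(OC)c1OC` is still unmeasured. It carries 2,4-dichlorophenyl in place of 4-bromophenyl on a double-bonded chain carbon bound to a double-bonded ring carbon.

Going by the values given here, only one measured step bears on this change, the exchange of chloro for bromo, and it stayed small: a 1.1-fold higher number from compound 1 to compound 2 (0.04 log units; within the scatter). That step replaces one halogen with another, whereas compound 3 has a second chlorine on the ring. Among the compounds with values here, no measured compound shows what a second halogen does, so the range is kept wide.

No shift beyond the scatter is expected in this assay, and the estimated change is a 1.2-fold lower number from compound 2 to compound 3 (0.07 log units; within the scatter). The expected value for compound 3 is 13000 nM, with an estimated range of 6500 nM to 26000 nM.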

Compound 3, half-maximal inhibitory concentration: 13400 nM
Compound 3: middle estimate off by 1.0-fold (0.01 log units), on the low side, and the stated range covers the measured number.
By their numbers in this assay, from the lowest: compounds 3, 1 and 2 (each within the scatter of the next).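

For the compounds shown here, compound 3 is the only compound here with a second halogen on this aromatic ring, and chloro in place of hydrogen on an aromatic carbon gives a 1.0-fold lower number from compound 1 to compound 3 (0.02 log units; within the scatter) in this assay. The exchange of 4-bromophenyl for 2,4-dichlorophenyl on a double-bonded chain carbon bound to a double-bonded ring carbon gives a 1.1-fold lower number from compound 2 to compound 3 (0.06 log units; within the scatter), so in this assay the second chlorine no more separates compound 3 from its neighbours than the halogen exchange separated the first pair. No measurement at hand offers a reason for this outcome.

On these data alone, all three compounds carry only halogens on this aromatic ring, so it remains open whether an amine, a carboxylic acid or a nitrile in their place would move the number beyond the scatter. The rest of the shared core is identical throughout, so these compounds say nothing about how a change elsewhere, such as a longer chain on the ring nitrogen, would read in this assay.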